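The compounds below may be only part of what the source reports. "The series", "measured", "known", "first", "only" and "open" are said of these compounds alone.

For the measured compounds named here, in an assay for positive allosteric modulation of metabotropic glutamate receptor 3 (Rattus norvegicus) (a lower number here means that less compound is needed, a higher number that more compound is needed for the effect), compound 2 `COc1cc(OC[C@H](C)COc2ccc(C(=O)CC(C)(C)C)c(O)c2C)ccc1C(=O)O` gives 1460 nM, which is the higher of the two numbers known so far, though the gap to its nearest neighbour is small. Going by the values given here, compound 1 `Cc1cc(OC[C@H](C)COc2ccc(C(=O)CC(C)(C)C)c(O)c2C)ccc1C(=O)O` gives 1350 nM in this assay, and the only step in hand, a 1.1-fold higher number from compound 1 to compound 2 (0.03 log units; within the scatter), shows that exchanging methyl for methoxy changes nothing beyond the scatter. Compound 3 `COc1cccc(OC[C@H](C)COc2ccc(C(=O)CC(C)(C)C)c(O)c2C)c1` differs from compound 2 by hydrogen in place of carboxy on an aromatic carbon, that is, the carboxy group is removed and the ring now carries a hydrogen at that position. Among the compounds with values here, no measured pair involves the carboxy group, so the step from compound 1 to compound 2 does not bear on this change, and there is nothing in the data to set its size. Because the loss of a whole group is a larger change than the one shown by a 1.1-fold higher number from compound 1 to compound 2 (0.03 log units; within the scatter), a step beyond the scatter toward a higher number is expected, and the estimate for compound 3 is the step of a 3.1-fold higher number from compound 2 to compound 3 (0.49 log units; beyond the scatter). Compound 3 is therefore expected to give about 4500 nM in this assay, within a range from 1200 nM to 20000 nM.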

Compound 3, half-maximal effective concentration: "not active" (no number reported)
Compound 3 has no reported number here; no gap can be computed for the estimate.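

For the compounds shown here, compound 3 is reported as "not active" in this assay with no number, so no step from compound 2 to compound 3 can be read. Nothing at hand offers an explanation for this result. The compounds shown leave open how large the effect of exchanging carboxy for hydrogen is on the number in this assay.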